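A Side-Chain Swap at the Edge of Measurement

The source may report more compounds than this note shows. Statements on the series, on what has been measured and on what is new or still open speak of the compounds shown alone.

Compound 2 `CCCCc1oc2ccccc2c1C(=O)c1ccc(OCC(=O)NCc2ccccc2)cc1` carries a benzylcarbamoyl group on a chain that ends at an oxygen on an aromatic ring of the shared core. In a functional assay on MDA-MB-231 cells (Homo sapiens) for antiproliferative activity, read by MTT assay, with a stated time of 24 h (a lower number here means a stronger inhibitor, a higher number a weaker inhibitor), compound 2 gives only a limit, > 50000 nM. Its nearest measured relative, compound 1 `CCCCc1oc2ccccc2c1C(=O)c1ccc(OCC(=O)N2CCCC2)cc1`, likewise reaches only a limit in this assay, > 50000 nM. Among the compounds with values here, the single step between them, a step that the two limits leave unreadable from compound 1 to compound 2, therefore cannot be read in size, and the one thing the two values share is that (the limit of > 50000 nM in this assay, at which 2 of the 2 values shown sit). Compound 3 `CCCCNC(=O)CCCOc1ccc(C(=O)c2c(CCCC)oc3ccccc23)cc1` is the next member, and the change from compound 2 is 2-(butylcarbamoyl)ethyl in place of benzylcarbamoyl on a saturated chain carbon bound to an oxygen on an aromatic ring. Within the data shown here, no measured step touches this part of the molecule in a readable way, so there is nothing to set a direction or a size for the move in this assay; the only guide is that every value seen so far is a limit. Compound 3 is therefore expected to land at or near that same limit, with a step that the limit leaves unreadable from compound 2 to compound 3 as the step its estimate implies. For compound 3 the estimated value is 60000 nM, within a range from 20000 nM to 200000 nM.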

Compound 3, half-maximal inhibitory concentration: 38100 nM
Compound 3: the middle estimate sits 1.6-fold (0.20 log units) above what was measured; the range from low to high includes it.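

Compound 3 is the first compound shown to give a number rather than a limit in this assay, so this position on the chain bound to the oxygen on the aromatic ring now has a readable value, 38100 nM. Set against the benzylcarbamoyl side chain, the change is an at least 1.3-fold lower number from compound 2 to compound 3 (0.11 log units; that floor lies within the scatter), and set against the (pyrrolidin-1-yl)carbonyl side chain, it is an at least 1.3-fold lower number from compound 1 to compound 3 (0.11 log units; that floor lies within the scatter). Both steps are floors rather than sizes, and the step between the two earlier compounds stays unreadable, so the result shows only that this side chain brings a value into measurable range, with compounds 1 and 2 remaining at a shared limit: the limit of > 50000 nM in this assay, at which 2 of the 3 values shown sit.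

The compounds shown leave open whether the longer chain or the butyl group on the amide matters here, since the two change together in this step, and a (butylcarbamoyl)methyl or a 3-(benzylcarbamoyl)propyl side chain would separate them. On these data alone, it also remains open how a still longer chain, or a carboxylic acid or an amine at the chain end, would read in this assay.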